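Compound 1 to compound 4: losing 2-chlorobenzyl

The source may hold more compounds than are shown below. What is called first, only, known or untested is meant among the compounds shown, and "the series" means these compounds.

Measured so far in a functional assay on NCI-H460 cells (Homo sapiens) for cytotoxicity, read by MTT assay, with a stated time of 72 h (on this read-out higher numbers stand for weaker inhibition and lower numbers for stronger inhibition), for this series:
- compound 1 `CN(C)Cc1ccc2nc(NC(=O)N/N=C/c3cn(Cc4ccccc4Cl)c4ccccc34)sc2c1` gives 1600 nM
- compound 2 `CC1CCN(Cc2ccc3nc(NC(=O)N/N=C/c4cn(Cc5cccc(Cl)c5)c5ccccc45)sc3c2)CC1` gives 280 nM
- compound 3 `CCN(CC)Cc1ccc2nc(NC(=O)N/N=C/c3cn(Cc4ccc(Cl)cc4Cl)c4ccccc34)sc2c1` gives 1080 nM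

Compound 1 (1600 nM) has the highest number of the three, but it lies within the scatter of compound 3 (1080 nM). Compound 2 (280 nM) is lower than compound 1 beyond the scatter. Compound 4 `CN(C)Cc1ccc2nc(NC(=O)N/N=C/c3c[nH]c4ccccc34)sc2c1` carries hydrogen in place of 2-chlorobenzyl on an aromatic nitrogen. Among the measured compounds shown here, no measured compound lacks a benzyl group at that nitrogen, and no single-place comparison exists, so the expectation is tentative. A moderate move to weaker inhibition is expected in this assay (estimated step a 2.5-fold higher number from compound 1 to compound 4 (0.40 log units; beyond the scatter)). The estimate for compound 4 is 4000 nM (expected range 1300 nM to 12000 nM).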

Compound 4, half-maximal inhibitory concentration: 2550 nM
For compound 4 the middle estimate is 1.6-fold (0.20 log units) above the measured one; low and high end bracket the measured number.
By their numbers in this assay, from the lowest: compound 2; then compounds 3, 1 and 4 (each within the scatter of the next, the first and the last beyond it).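

Among the compounds shown here, the first single-place comparison in this assay gives a 1.6-fold higher number from compound 1 to compound 4 (0.20 log units; within the scatter). At this aromatic nitrogen, the whole 2-chlorobenzyl group, with its six-membered aromatic ring, can therefore give way to hydrogen without a change beyond the scatter, at least on the core of compound 1. No supporting measurement bears on this result.

Going by these compounds, it remains open whether a methyl group or a longer chain such as n-butyl on this nitrogen would depart from compound 4. Also open, on these data alone, is whether hydrogen there would give a similarly small step on the cores of compound 2 and compound 3.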